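A Sulfur-Bearing Ring Swap and Expected Microsomal Half-Life

The source may hold more compounds than are shown below. What is called first, only, known or untested is meant among the compounds shown, and "the series" means these compounds.

Compound 1 `C/C(=C1/OC(=O)NC1=O)C(c1ccc(-c2ccc3cccc(F)c3c2)[nH]c1=O)C(C)C` is followed here toward compound 3 `CC(C)C(/C=C1\SC(=O)NC1=O)c1ccc(-c2ccc3cccc(F)c3c2)[nH]c1=O` in an ADME assay on microsomes from liver (Rattus norvegicus) for metabolic stability; on this read-out higher numbers stand for a longer-lived compound and lower numbers for a shorter-lived compound. In this assay compound 1 gives > 3 h, which is a limit of the assay and not a number. Compound 1 therefore stands at the limit of > 3 h in this assay, at which 1 of the 2 values shown sits. The other measured compound, compound 2 `CC(C)[C@H](C[C@@H]1OC(=O)NC1=O)c1ccc(-c2ccc3cccc(F)c3c2)[nH]c1=O`, gives 0.503 h in this assay. For the measured compounds named here, no step between measured compounds that differ in a single place is available, so the two values show only where each compound stands. Compound 3 differs from compound 1 by a group of 8 heavy atoms (4 carbon, 1 nitrogen, 2 oxygen, 1 sulfur; one five-membered non-aromatic ring with 2 hetero atoms) in place of a group of 9 heavy atoms (5 carbon, 1 nitrogen, 3 oxygen; one five-membered non-aromatic ring with 2 hetero atoms), on a saturated chain carbon bound to an aromatic carbon and a saturated chain carbon. Nothing measured bears on this change, so in this assay the step from compound 1 to compound 3 is expected to stay within the usual scatter or to fall only slightly. On that basis compound 3 is estimated at 2.5 h, within 1 h to 6 h. This corresponds to an expected step of an at least 1.2-fold lower number from compound 1 to compound 3 (0.07 log units; that floor lies within the scatter).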

Compound 3, half-life: 2.62 h
Compound 3: the middle estimate sits 1.0-fold (0.02 log units) below what was measured, and the stated range covers the measured number.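

In this assay compound 1 gives > 3 h, which is a limit of the assay and not a number. At the saturated chain carbon bound to an aromatic carbon and a saturated chain carbon, the group of 9 heavy atoms gives way to the sulfur-bearing group of 8 heavy atoms, and the result is an at least 1.1-fold lower number from compound 1 to compound 3 (0.05 log units; that floor lies within the scatter), so this position now has a measured sulfur-bearing ring, with compound 3 at 2.62 h. The step can be read only as a floor because one end of it is not a number: the limit of > 3 h in this assay, at which 1 of the 3 values shown sits.

The two groups differ both in sulfur against oxygen and in their carbon count, and the compounds shown do not separate these two differences. From the compounds shown here alone, how an amine or a carboxylic acid at this carbon would behave also stays open.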